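From 2-fluorobenzyl to 3-fluorobenzyl in compound 3

The source may hold more compounds than are shown below. What is called first, only, known or untested is meant among the compounds shown, and "the series" means these compounds.

In a functional assay on GBM1 cells (Homo sapiens) for antiproliferative activity, read by WST assay, with a stated time of 72 h (a higher number here means a weaker inhibitor, a lower number a stronger inhibitor), compound 1 (`O=C(Nc1ccc(C(F)(F)F)cc1)Nc1cc2ncncc2cc1OCc1cccc(F)c1`) gives 3800 nM and compound 2 (`O=C(Nc1ccc(Cl)c(Cl)c1)Nc1cc2ncncc2cc1OCc1ccccc1F`) gives 4100 nM and these two numbers lie within the scatter of each other. Among the compounds with values here, compound 2 therefore stands level with the only other measured compound. Compound 3 (`O=C(Nc1ccc(Cl)c(Cl)c1)Nc1cc2ncncc2cc1OCc1cccc(F)c1`) has yet to be measured. It differs from compound 2 by 3-fluorophenyl in place of 2-fluorophenyl on a saturated chain carbon bound to an oxygen on an aromatic ring with 3-fluorophenyl in place of 2-fluorophenyl on a saturated chain carbon bound to an oxygen on an aromatic ring. Within the data shown here, no measured pair isolates this change, so the data give it no direct size. Starting from compound 2 at 4100 nM as the reference, no step beyond the scatter is expected in this assay in either direction. The expected step runs a 1.1-fold lower number from compound 2 to compound 3 (0.03 log units; within the scatter) and stays within the scatter. Compound 3 is estimated at 3800 nM with an expected range of 1700 nM to 8000 nM for this read-out.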

Compound 3, half-maximal inhibitory concentration: 2100 nM
The estimate for compound 3 lay 1.8-fold (0.26 log units) above the measured number, within the range that was stated.
By their numbers in this assay, from the lowest: compounds 3, 1 and 2 (each within the scatter of the next).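

Placing the fluorine differently on the benzyl group, 3-fluorobenzyl in place of 2-fluorobenzyl on the oxygen, gives the first direct reading at this position: a 2.0-fold lower number from compound 2 to compound 3 (0.29 log units; within the scatter) in this assay and lies within the scatter, so the two fluorobenzyl groups cannot be told apart here. The same holds on the amide-type nitrogen, where 3,4-dichlorophenyl in place of 4-(trifluoromethyl)phenyl gives a 1.8-fold lower number from compound 1 to compound 3 (0.26 log units; within the scatter) and also stays within the scatter. Nothing further is available that bears on this result.

As far as these compounds go, whether an unsubstituted benzyl, a methyl ether or a longer chain carrying an amine at this place would give a step beyond the scatter stays open. Equally open, from the compounds shown here alone, is how a carboxylic acid on the aryl group of the amide-type nitrogen would read.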